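Neopentyl to cyclobutylmethyl on the amide of the series

The compounds below may be only part of what the source reports. "The series", "measured", "known", "first", "only" and "open" are said of these compounds alone.

Three measured compounds share one core. Compound 1 `C[C@@H](NC(=O)c1ccc(C#Cc2cccc(F)c2)cn1)C(C)(C)C` gives 66% in a functional assay on HEK293 cells for positive allosteric modulation of metabotropic glutamate receptor 5 (Rattus norvegicus), read by fluorescence and calcium flux (on this read-out lower numbers stand for smaller maximal responses and higher numbers for larger maximal responses), and compound 2 `C[C@H](NC(=O)c1ccc(C#Cc2cccc(F)c2)cn1)C(C)(C)C` gives 70.8%; the step of a number 4.8 percentage points higher from compound 1 to compound 2 (within the scatter) rests on (the fact that compounds 1 and 2 differ only in the configuration as drawn). Compound 3 `CC(C)(C)CNC(=O)c1ccc(C#Cc2cccc(F)c2)cn1` gives 63.9%; its number is the smallest of the three, a difference that a number 2.1 percentage points lower from compound 1 to compound 3 (within the scatter) and a number 6.9 percentage points lower from compound 2 to compound 3 (within the scatter) show to lie within the scatter. Compound 4 `O=C(NCC1CCC1)c1ccc(C#Cc2cccc(F)c2)cn1` differs from compound 3 by cyclobutyl in place of tert-butyl on a saturated chain carbon bound to an amide-type nitrogen. Among the compounds with values here, no measured step exchanges tert-butyl for a ring; the nearest steps, hydrogen in place of methyl on the same saturated chain carbon, stayed within the scatter. A step of no more than the scatter is therefore expected for a number 0.1 percentage points higher from compound 3 to compound 4 (within the scatter). Compound 4 is estimated at 64%, between 50% and 78%.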

Compound 4, largest response reached (reported as efficacy), in percent of the reference or control that the assay uses: 68.1%
For compound 4 the middle estimate is 4.1 percentage points below the measured one; the measured number falls inside the stated range.
By their numbers in this assay, from the lowest: compounds 3, 1, 4 and 2 (each within the scatter of the next).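

In this assay the step to a ring on this saturated chain carbon, cyclobutyl in place of tert-butyl, gives a number 4.2 percentage points higher from compound 3 to compound 4 (within the scatter). Cyclobutylmethyl in place of 1,2,2-trimethylpropyl on the amide-type nitrogen gives a number 2.7 percentage points lower from compound 2 to compound 4 (within the scatter) and a number 2.1 percentage points higher from compound 1 to compound 4 (within the scatter), so compound 4 cannot be told apart from any of the three earlier compounds. Nothing given here bears on the cause of these steps.

Open, on these data alone, is how cyclopropyl or cyclopentyl on the same saturated chain carbon would read. Also open, as far as these compounds go, is whether an amine, a carboxylic acid or a longer chain there would leave the maximal response within the scatter.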